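The compounds below may be only part of what the source reports. "The series", "measured", "known", "first", "only" and "open" are said of these compounds alone.

Measured compounds:
Compound 1 `COc1cc(Cl)cc(-c2nn(-c3cccc(NC(=O)c4cc(C(F)(F)F)cc(C(F)(F)F)c4)c3)cc2-c2ccncc2)c1` gives 58.6% in a functional assay on HCT-15 cells (Homo sapiens) for inhibition, read by sulforhodamine B assay, with a stated time of 48 h, tested at 10 uM; a higher number here means a weaker effect of the compound at the concentration tested, a lower number a stronger effect.
Compound 2 `COc1cc(Cl)cc(-c2nn(-c3cccc(NC(=O)c4ccc(Cl)c(Cl)c4)c3)cc2-c2ccncc2)c1` gives 57.9% in this assay.

Compound 2 holds the lowest of the two numbers in this assay, but its nearest neighbour is compound 1, whose value sits only slightly higher, a gap that lies within the usual scatter of such measurements. The two compounds share a common core and differ only in the aroyl part of the amide, and what their numbers show is that this exchange left the read-out essentially unchanged.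

The account now turns to compound 3 `COc1cc(Cl)cc(-c2nn(-c3cccc(NC(=O)Nc4ccc(Cl)c(Cl)c4)c3)cc2-c2ccncc2)c1`, which has not yet been measured. Relative to compound 2 the change is (3,4-dichlorophenyl)amino in place of 3,4-dichlorophenyl on a carbonyl carbon. Among the measured compounds shown here, no pair of measured compounds in this set carries that kind of change, so there is no measured step from which its size could be read. Going only by the two values at hand, which sit close together, the step from compound 2 to compound 3 is expected to be small, a number 2.1 percentage points higher from compound 2 to compound 3 (within the scatter), and not clearly beyond the scatter in either direction. For compound 3 the value in this assay is therefore estimated at 60%, with a range from 40% to 80%.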

Compound 3, a percentage reported as activity, at one concentration (the size of the read-out at that concentration, not a potency): 13.9%
The estimate for compound 3 lay 46.1 percentage points above the measured number, and the stated range ends above it.
By their numbers in this assay, from the lowest: compound 3; then compounds 2 and 1 (each within the scatter of the next).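

Among the compounds shown here, the step in this assay, a number 44 percentage points lower from compound 2 to compound 3 (beyond the scatter), shows that this position responds strongly to what links the carbonyl carbon to the 3,4-dichlorophenyl ring, something the earlier compounds could not show. Compounds 1 and 2 differ only in the substituents on that aromatic ring and stand within the scatter of each other, whereas placing (3,4-dichlorophenyl)amino on the carbonyl carbon, which keeps the same ring and adds a single nitrogen carrying one hydrogen-bond donor, produces a large step beyond the scatter. This single pair cannot separate the contribution of the added nitrogen from that of its hydrogen, and nothing available explains why the read-out responds to this change.

The compounds shown leave open whether the same exchange would produce a step of similar size on the ring of compound 1, which carries two trifluoromethyl groups. They also leave open whether the link itself depends on that hydrogen, as a methyl group on the new nitrogen or an oxygen in its place would test.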